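Fluoro step on the hydroxy-chain series

A few compounds are considered here, and "the series" means these few. Any claim that something is new, unique, unknown or untested is made for them only; others in the source may bear on it.

Measured in a functional assay on J774 cells (Mus musculus) for cytotoxicity, read by resazurin assay; a higher number here means a weaker inhibitor, a lower number a stronger inhibitor:
- compound 1 `OCCCCCC(O)c1ccc(-c2ccccc2)cc1`: 22000 nM
- compound 2 `OCCCCCC(O)c1ccc(-c2ccc(F)cc2)cc1`: 18000 nM
- compound 3 `OCCCCCC(O)c1ccc(-c2ccc(O)cc2)cc1`: 15000 nM

Compound 1 lies within the scatter of both other compounds, so the three values give no order. Compound 4 `OCCCCCC(O)c1ccc(-c2ccccc2)c(F)c1` differs from compound 1 by fluoro in place of hydrogen on an aromatic carbon, ortho to a phenyl group. The closest measured precedent is the fluoro step a 1.2-fold lower number from compound 1 to compound 2 (0.09 log units; within the scatter), made at a different place. The hydroxy step a 1.5-fold lower number from compound 1 to compound 3 (0.17 log units; within the scatter) also bears on it. Both steps stay within the scatter, so no shift beyond the scatter is expected in this assay. The expected step is a 1.2-fold lower number from compound 1 to compound 4 (0.06 log units; within the scatter). For compound 4 the estimated value is 19000 nM, with an expected range of 11000 nM to 32000 nM.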

Compound 4, half-maximal inhibitory concentration: 17000 nM
Compound 4: the middle estimate sits 1.1-fold (0.05 log units) above what was measured, and the stated range covers the measured number.
By their numbers in this assay, from the lowest: compounds 3, 4, 2 and 1 (each within the scatter of the next).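

In this assay, fluoro on an aromatic carbon ortho to a phenyl group gives a 1.3-fold lower number from compound 1 to compound 4 (0.11 log units; within the scatter), and this is the second place on the core of compound 1 to take fluoro. Neither the place in compound 2 nor this one gives a step beyond the scatter. No measurement shown here accounts for the size of either step.

On these data alone, whether an amine or a carboxylic acid at this same place would give a step beyond the scatter stays open. So does the effect of a longer chain in place of the hydroxy chain.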